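This account rests on a few compounds, and the source may have more. Where it says the series, first, only, none or still open, it means among the compounds named here.

Series notes. Compound 3 `O=C(O)/C=C/c1nc(CSc2c(Cl)cccc2Cl)ccc1OCCc1ccc(F)cc1` gives 1.5 nM in an assay on isolated protein for binding affinity to leukotriene B4 receptor 1 (Homo sapiens) (on this read-out lower numbers stand for stronger inhibition and higher numbers for weaker inhibition), and stands level with compound 1 `COc1ccc(CCCCOc2ccc(CSc3c(Cl)cccc3Cl)nc2/C=C/C(=O)O)cc1`, which gives 1.5 nM in this assay; against compound 2 `COc1ccc(CCOc2ccc(CSc3c(Cl)cccc3Cl)nc2/C=C/C(=O)O)cc1`, which gives 1.2 nM in this assay, the difference is a 1.3-fold higher number from compound 2 to compound 3 (0.10 log units; within the scatter), so the three numbers do not separate from one another. Compound 4 `O=C(O)/C=C/c1nc(CSc2c(Cl)cccc2Cl)ccc1OCc1ccc(F)cc1` is not yet measured in this assay. It differs from compound 3 by 4-fluorophenyl in place of 4-fluorobenzyl on a saturated chain carbon bound to an oxygen on an aromatic ring. The measured steps that bear on this change are a 1.3-fold lower number from compound 1 to compound 2 (0.10 log units; within the scatter) and no change at the digits printed from compound 1 to compound 3 (within the scatter); each removes two saturated chain carbons at the same kind of place as the present change, and each stays within the scatter. The exchange of methoxy for fluoro, a 1.3-fold higher number from compound 2 to compound 3 (0.10 log units; within the scatter), also stays within the scatter. On this basis no step beyond the scatter is expected for compound 4 in this assay, the expected change being no change at the digits printed from compound 3 to compound 4 (within the scatter). Compound 4 is accordingly estimated at 1.5 nM, with an expected range from 0.7 nM to 3.5 nM.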

Compound 4, inhibition constant: 12 nM
Estimate against measurement, compound 4: 8.0-fold (0.90 log units) below, outside the stated range (above it).
By their numbers in this assay, from the lowest: compounds 2, 1 and 3 (each within the scatter of the next); then compound 4.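

In this assay, going from 2-(4-fluorophenyl)ethyl to 4-fluorobenzyl at this place gives an 8.0-fold higher number from compound 3 to compound 4 (0.90 log units; beyond the scatter) and is the first change in the series to leave the scatter, so the tolerance of chain length seen across compound 1, compound 2 and compound 3 does not reach the shortest chain shown. The steps to the methoxy compounds point the same way, with a 10-fold higher number from compound 2 to compound 4 (1.00 log units; beyond the scatter) and an 8.0-fold higher number from compound 1 to compound 4 (0.90 log units; beyond the scatter), although each of these also exchanges the methoxy for fluoro. Nothing at hand gives a reason for this loss at the shortest chain.

Going by these compounds, whether 4-methoxybenzyl at this place would show the same step remains open. Also open, on these data alone, is how a longer chain carrying an amine or an amide would read at this place.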